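Swapping 4-Chlorophenyl for 2-Phenylethynyl: Expecting Compound 3

A few compounds are considered here, and "the series" means these few. Any claim that something is new, unique, unknown or untested is made for them only; others in the source may bear on it.

Two compounds have so far been measured in an assay on CHO cells for antagonist activity at transient receptor potential cation channel subfamily V member 1 (Homo sapiens), read by FLIPR; on this read-out higher numbers stand for weaker inhibition and lower numbers for stronger inhibition:
compound 1 `CC(C(=O)NCc1ccc(C(F)(F)F)nc1-c1ccc(Cl)cc1)c1ccc(NS(C)(=O)=O)c(F)c1`, 0.7 nM
compound 2 `CC(C(=O)NCc1ccc(C(F)(F)F)nc1-c1ccoc1)c1ccc(NS(C)(=O)=O)c(F)c1`, 1.4 nM

Among the measured compounds shown here, compound 1 stands at the lower of the two numbers; its only neighbour is compound 2, and the step of a 2.0-fold higher number from compound 1 to compound 2 (0.30 log units; within the scatter), so the two cannot be told apart on this read-out.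

Compound 3 `CC(C(=O)NCc1ccc(C(F)(F)F)nc1C#Cc1ccccc1)c1ccc(NS(C)(=O)=O)c(F)c1` has not yet been measured. It differs from compound 1 in one place: 2-phenylethynyl in place of 4-chlorophenyl on an aromatic carbon. For the measured compounds named here, the single measured step that touches this aromatic carbon is a 2.0-fold higher number from compound 1 to compound 2 (0.30 log units; within the scatter), where one aromatic group replaced another without moving the number beyond the scatter. Going by the values given here, no measured step involves 2-phenylethynyl, so the record gives no direct precedent for it. Because a 2.0-fold higher number from compound 1 to compound 2 (0.30 log units; within the scatter) shows the group on this carbon to be exchangeable without a large shift, only a small drift toward a higher number is expected for compound 3, a 2.1-fold higher number from compound 1 to compound 3 (0.33 log units; beyond the scatter). The estimate for compound 3 in this assay is 1.5 nM, with a range from 0.4 nM to 6 nM.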

Compound 3, inhibition constant: 0.8 nM
For compound 3 the middle estimate is 1.9-fold (0.27 log units) above the measured one; the measured number falls inside the stated range.
By their numbers in this assay, from the lowest: compounds 1, 3 and 2 (each within the scatter of the next).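

In this assay, the phenylethynyl result widens what this aromatic carbon, next to the ring nitrogen and ortho to a large group, is known to accept: until now it had carried only a ring of the 4-chlorophenyl or furan-3-yl kind, whereas 2-phenylethynyl brings a triple bond outside aromatic rings and one more heavy atom than the group it replaces. That exchange gives a 1.1-fold higher number from compound 1 to compound 3 (0.06 log units; within the scatter), and the comparison with the furan gives a 1.8-fold lower number from compound 2 to compound 3 (0.24 log units; within the scatter), so neither step separates the compounds on this read-out. The three compounds therefore cannot be told apart, and the alkyne-linked phenyl joins the two aromatic groups as a tolerated replacement at this carbon, with no group shown so far that moves the number beyond the scatter.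

What the compounds shown leave open is where this tolerance ends, for instance whether a saturated ring such as piperidine, a simple amine, a carboxylic acid or a short alkyl chain on this carbon would also leave the number in the same place. Nothing available here accounts for the three compounds reading alike.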